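The source may report more compounds than this note shows. Statements on the series, on what has been measured and on what is new or still open speak of the compounds shown alone.

Among the measured compounds shown here, compound 1 `O=c1c(C2N=C(c3ccccc3)SS2)coc2ccc(F)cc12` stands highest of the two numbers so far: in a functional assay on COLO 205 cells (Homo sapiens) for inhibition, read by sulforhodamine B assay, with a stated time of 48 h, tested at 100 uM (a higher number here means more inhibition of growth at the concentration tested, a lower number less inhibition of growth), compound 1 gives 37%, while its nearest neighbour, compound 2 `O=c1c(C2N=C(c3ccccc3)SS2)coc2ccccc12`, gives 18%, a step of a number 19 percentage points lower from compound 1 to compound 2 (beyond the scatter) that lies beyond the scatter. Compound 3 `O=c1c(C2N=C(c3ccccc3)SS2)coc2cc(Cl)c(F)cc12` has not yet been measured; it differs from compound 1 by chloro in place of hydrogen on an aromatic carbon. For the measured compounds named here, the one measured step concerns removing the fluoro group, not adding a chloro group, so no measured step bears directly on this change. The step from compound 1 is therefore expected to be a number 8 percentage points higher from compound 1 to compound 3 (within the scatter). Compound 3 is estimated at 45%, in a range from 25% to 65%.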

Compound 3, percent growth inhibition at one concentration: 45%
Compound 3: the middle estimate sits on the measured number at the digits printed; low and high end bracket the measured number.
By their numbers in this assay, from the lowest: compound 2; then compounds 1 and 3 (each within the scatter of the next).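

Chloro in place of hydrogen, on the aromatic carbon ortho to a fluoro group, gives a number 8 percentage points higher from compound 1 to compound 3 (within the scatter) in this assay. Among the compounds shown here, the fluoro-bearing ring of compound 1 thus takes a chloro group at this position without a step beyond the scatter, which the earlier compounds could not show. Nothing measured here explains this result. As far as these compounds go, whether an amine, a methoxy group or a carboxylic acid would be accepted on this carbon remains open, as does what chloro does there without the fluoro group.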